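This account rests on a few compounds, and the source may have more. Where it says the series, first, only, none or still open, it means among the compounds named here.

In a functional assay on HEK293 cells for antagonist activity at Voltage-dependent L-type calcium channel subunit alpha-1D (Rattus norvegicus), read by FLIPR (a lower number here means a stronger inhibitor, a higher number a weaker inhibitor), compound 1 `CCOC(=O)C1=C(C)NC(COC(C)=O)=C(C(=O)OCC)C1c1cccc([N+](=O)[O-])c1` gives 37 nM, and compound 2 `CCOC(=O)C1=C(C)NC(/C=C/c2ccc([N+](=O)[O-])cc2)=C(C(=O)OCC)C1c1cccc([N+](=O)[O-])c1` gives 2060 nM. Among the measured compounds shown here, the one measured step, a 56-fold higher number from compound 1 to compound 2 (1.75 log units; beyond the scatter), changes a group on a double-bonded ring carbon of the shared core. Compound 3 `COC(=O)C1=C(C)NC(C)=C(C(=O)OCc2cc([N+](=O)[O-])cc([N+](=O)[O-])c2)C1c1cccc([N+](=O)[O-])c1` gives 40 nM in this assay; it stands second highest of the three numbers, with compound 1 nearest and within the scatter of it, and compound 2 furthest, far beyond the scatter.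

Compound 4 `COC(=O)C1=C(C)NC(C)=C(C(=O)OCc2ccc(-c3ccccc3)cc2)C1c1cccc([N+](=O)[O-])c1` is not yet measured. It differs from compound 3 in one place: 4-phenylphenyl in place of 3,5-dinitrophenyl on a saturated chain carbon bound to an oxygen next to a carbonyl group. For the measured compounds named here, no measured step touches this position; the step from compound 1 to compound 2 concerns another part of the core and so does not bear on it directly, and the near-equal numbers of compound 1 and compound 3 show only that two quite different ester groups give similar numbers. On that basis he expects for compound 4 a step of a 1.5-fold higher number from compound 3 to compound 4 (0.18 log units; within the scatter) in this assay, likely within or near the scatter. His estimate for compound 4 is 60 nM, between 15 nM and 250 nM.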

Compound 4, half-maximal inhibitory concentration: 74 nM
Compound 4: the middle estimate sits 1.2-fold (0.09 log units) below what was measured; the range from low to high includes it.
By their numbers in this assay, from the lowest: compounds 1, 3 and 4 (each within the scatter of the next); then compound 2.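

In this assay, the swap of 3,5-dinitrophenyl for 4-phenylphenyl on a saturated chain carbon bound to an oxygen next to a carbonyl group stays within the scatter (a 1.9-fold higher number from compound 3 to compound 4 (0.27 log units; within the scatter)). This position therefore accepts two groups of 12 heavy atoms each with no readable difference, although the entering group is all carbon with two aromatic rings and the leaving group has one ring, two nitrogens and four oxygens. Nothing available explains why the two groups read alike.

The compounds shown leave open whether a smaller or charged group here, such as a plain methyl, an amine or a carboxylic acid, would also stay within the scatter. They also leave open whether a longer chain carrying the 4-phenylphenyl group would do so.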